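Chain-length epimer pair in the hydroxypyrrolidine series

The source may report more compounds than this note shows. Statements on the series, on what has been measured and on what is new or still open speak of the compounds shown alone.

Measured so far in a functional assay on PC-3 cells (Homo sapiens) for antiproliferative activity, read by MTT assay, with a stated time of 72 h; a lower number here means a stronger inhibitor, a higher number a weaker inhibitor:
compound 1, `CCCCCCCCCCNC[C@@H]1OC[C@H](N)[C@@H]1O`, 11900 nM
compound 2, `CCCCCCCCCCCCNC[C@@H]1OC[C@H](N)[C@H]1O`, 2380 nM
compound 3, `CCCCCCCCCCCCNC[C@@H]1OC[C@H](N)[C@@H]1O`, 850 nM

Compound 2 gives the second highest of the three numbers; its nearest neighbour is compound 3, a 2.8-fold lower number from compound 2 to compound 3 (0.45 log units; beyond the scatter), the two sharing all atoms and bonds (the fact that compounds 2 and 3 differ only in the configuration as drawn), and its furthest is compound 1. The unmeasured compound 4, `CCCCCCCCCCNC[C@@H]1OC[C@H](N)[C@H]1O`, differs from compound 2 by hydrogen in place of ethyl on a saturated chain carbon, ten or more bonds along the chain from an amine nitrogen. Within the data shown here, the one step that bears on this is the reverse of it: a 14-fold lower number from compound 1 to compound 3 (1.15 log units; beyond the scatter). A step of similar size in the opposite direction is therefore expected in this assay, a 14-fold higher number from compound 2 to compound 4 (1.14 log units; beyond the scatter). Compound 4 is estimated at 33000 nM, within 12000 nM to 90000 nM.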

Compound 4, half-maximal inhibitory concentration: > 128000 nM
Compound 4 was reported as a limit (the forecaster's own chance of this, stated with the estimate: 15%); at least 3.8-fold (0.58 log units) between middle value and limit.
By their numbers in this assay, from the lowest: compound 3; then compound 2; then compound 1. At a limit, above all of these: compound 4.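

Compound 4 gives > 128000 nM in this assay, which is a limit and not a number. On this epimer, hydrogen in place of ethyl gives an at least 53-fold higher number from compound 2 to compound 4 (1.73 log units; beyond the scatter), and the change does not carry over evenly between the two epimers: the same change on two cores in this assay, a 14-fold lower number (1.15 log units; beyond the scatter) from compound 1 to compound 3 and an at least 53-fold lower number (1.73 log units; beyond the scatter) from compound 4 to compound 2, at least 3.8-fold (0.58 log units) apart, beyond the scatter of two such steps The ring stereocentre also still counts with hydrogen in place of ethyl, giving an at least 10-fold higher number from compound 1 to compound 4 (1.03 log units; beyond the scatter), in the same sense as a 2.8-fold lower number from compound 2 to compound 3 (0.45 log units; beyond the scatter).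

As far as these compounds go, how a longer chain would behave on either epimer stays open. So does the size of the drop for compound 4, since only a limit is available.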